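From 4-chlorophenyl to (pyridin-2-yl)oxy on a saturated ring

A few compounds are considered here, and "the series" means these few. Any claim that something is new, unique, unknown or untested is made for them only; others in the source may bear on it.

Compound 1 `O=C(Nc1cc(-c2ccccn2)n[nH]1)N1CCC(c2cccc(F)c2)CC1` gives 25.3 mL.min-1.g-1
Compound 2 `O=C(Nc1cc(-c2ccccn2)n[nH]1)N1CCC(c2ccc(Cl)cc2)CC1` gives 30 mL.min-1.g-1

Going by the values given here, in an ADME assay on liver for metabolic stability, with Liver microsome (Homo sapiens) as the target, using microsomes (on this read-out higher numbers stand for fast clearance and lower numbers for slow clearance), compound 2 stands level with compound 1, and the only measured step of a 1.2-fold higher number from compound 1 to compound 2 (0.07 log units; within the scatter) lies within the scatter. Compound 3 `O=C(Nc1cc(-c2ccccn2)n[nH]1)N1CCC(Oc2ccccn2)CC1` differs from compound 2 by (pyridin-2-yl)oxy in place of 4-chlorophenyl on a saturated ring carbon with (pyridin-2-yl)oxy in place of 4-chlorophenyl on a saturated ring carbon. Among the compounds with values here, the measured step only exchanges one substituted phenyl for another, so it offers little guidance here, and no measured compound carries a ring with a hetero atom. The estimated step of a 1.9-fold lower number from compound 2 to compound 3 (0.27 log units; within the scatter) is a moderate, tentative expectation towards a lower number. Compound 3 is expected at 16 mL.min-1.g-1 with an estimated range of 7 mL.min-1.g-1 to 32 mL.min-1.g-1 on this read-out.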

Compound 3, intrinsic clearance in microsomes: < 11.9 mL.min-1.g-1
Compound 3 ended at the assay's limit (the forecaster's own chance of this, stated with the estimate: 5%); middle value at least 1.3-fold (0.12 log units) from the limit.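

At this saturated ring carbon, the read-out in this assay does respond to the group carried, which the exchange of one substituted phenyl for another did not show. The change to (pyridin-2-yl)oxy gives an at least 2.5-fold lower number from compound 2 to compound 3 (0.40 log units; beyond the scatter), and likewise an at least 2.1-fold lower number from compound 1 to compound 3 (0.32 log units; beyond the scatter). The value of compound 3 is a limit of the assay and not a number, so both steps give only a minimum size: the limit of < 11.9 mL.min-1.g-1 in this assay, at which 1 of the 3 values shown sits.

Going by these compounds, whether the oxygen or the nitrogen of (pyridin-2-yl)oxy carries the step stays open. A phenoxy group at this place, or a pyridin-2-yl group bonded directly to the ring carbon, would separate the two.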